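A few compounds are considered here, and "the series" means these few. Any claim that something is new, unique, unknown or untested is made for them only; others in the source may bear on it.

Working notes on the aryl variation at the carbon with a double bond to nitrogen, all compounds sharing the core of compound 1 `CN(C)CCn1cnnc1-c1cc(Oc2ccc(NC(=O)N/N=C/c3cc(C(C)(C)C)cc(C(C)(C)C)c3O)cc2F)ccn1`. In a functional assay on NCI-H460 cells (Homo sapiens) for cytotoxicity, read by MTT assay, with a stated time of 72 h (a higher number here means a weaker inhibitor, a lower number a stronger inhibitor), compound 1 gives 590 nM. Compound 2 `COc1ccc(/C=N/NC(=O)Nc2ccc(Oc3ccnc(-c4nncn4CCN(C)C)c3)c(F)c2)c(OC)c1OC` gives 1790 nM in this assay, and compound 3 `CN(C)CCn1cnnc1-c1cc(Oc2ccc(NC(=O)N/N=C/c3ccc(F)cc3)cc2F)ccn1` gives 1980 nM. Among the compounds with values here, compound 2 thus sits second highest of the three numbers: compound 3 is nearest, and the change a 1.1-fold higher number from compound 2 to compound 3 (0.04 log units; within the scatter), so the two cannot be told apart; compound 1 is furthest, its value below that of compound 2 by more than the scatter, though no single-point step between compound 1 and compound 2 is set out here.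

Compound 4 `CN(C)CCn1cnnc1-c1cc(Oc2ccc(NC(=O)N/N=C/c3cccc(Cl)c3Cl)cc2F)ccn1` is not yet measured. Relative to compound 2 the change is 2,3-dichlorophenyl in place of 2,3,4-trimethoxyphenyl on a carbon with a double bond to nitrogen. Within the data shown here, the one measured step at this position, a 1.1-fold higher number from compound 2 to compound 3 (0.04 log units; within the scatter), shows that swapping the trimethoxyphenyl for a small halogenated phenyl left this assay essentially unchanged. Compound 1 shows that a differently substituted phenyl can lower the number, but 2,3-dichlorophenyl resembles 4-fluorophenyl more than the di-tert-butyl hydroxyphenyl of compound 1. The expected step is therefore a 1.4-fold lower number from compound 2 to compound 4 (0.14 log units; within the scatter), at most a modest lowering and possibly none beyond the scatter. For compound 4 the estimate in this assay is 1300 nM, with a range from 500 nM to 3500 nM.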

Compound 4, half-maximal inhibitory concentration: 72 nM
The estimate for compound 4 lay 18-fold (1.26 log units) above the measured number; the measured number lies below the stated range.
By their numbers in this assay, from the lowest: compound 4; then compound 1; then compounds 2 and 3 (each within the scatter of the next).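

In this assay, the position on the carbon with a double bond to nitrogen proves far more sensitive to the aryl group than the earlier step suggested: replacing 2,3,4-trimethoxyphenyl with 2,3-dichlorophenyl gives a 25-fold lower number from compound 2 to compound 4 (1.40 log units; beyond the scatter) and replacing 4-fluorophenyl with 2,3-dichlorophenyl gives a 28-fold lower number from compound 3 to compound 4 (1.44 log units; beyond the scatter), against only a 1.1-fold higher number from compound 2 to compound 3 (0.04 log units; within the scatter) for the first halogenated phenyl tried. Halogen on the phenyl does not by itself bring a low number among these compounds, since compound 3 carries a halogen and goes against any such pattern, so the outcome depends on which halogenated phenyl is present. Within the data shown here, a low number also does not need the di-tert-butyl hydroxyphenyl: compound 1 gives 590 nM and compound 4, without that group, gives 72 nM (no step between these two is set out).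

No data shown here explain the size of these steps. The compounds shown leave open whether both chlorines are needed, and whether a phenyl carrying a single chlorine, a dimethylphenyl or an aminophenyl at this position would keep the number of compound 4.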